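Swapping a Urea Tail for a Carbamate Tail

The source may hold more compounds than are shown below. What is called first, only, known or untested is meant among the compounds shown, and "the series" means these compounds.

Measured so far:
Compound 1 `CC(C)(C)NC(=O)NCCS(=O)(=O)NC(=O)c1ccc(Nc2nc(NC3(c4ccc(Cl)cc4)CC3)nc(OCC(F)(F)F)n2)cc1`: 96%
Compound 2 `CS(=O)(=O)NC(=O)c1ccc(Nc2nc(NC3(c4ccc(Cl)cc4)CC3)nc(OCC(F)(F)F)n2)cc1`: 100%

In an ADME assay on microsomes from liver (Homo sapiens) for metabolic stability, with a stated time of 10 min (a higher number here means that more of the compound is left, a lower number that less of the compound is left), compound 1 stands lowest of the two numbers, with compound 2 nearest; the step of a number 4 percentage points higher from compound 1 to compound 2 (within the scatter) lies within the scatter, so the two cannot be told apart. Compound 3 `COC(=O)NCCS(=O)(=O)NC(=O)c1ccc(Nc2nc(NC3(c4ccc(Cl)cc4)CC3)nc(OCC(F)(F)F)n2)cc1` differs from compound 1 by methoxy in place of (tert-butyl)amino on a carbonyl carbon. Among the measured compounds shown here, the only measured step removes the whole (((tert-butyl)carbamoyl)amino)methyl group and still moves nothing beyond the scatter, so a smaller change inside that tail is expected to matter even less. The expected step is no change at the digits printed from compound 1 to compound 3 (within the scatter), none beyond the scatter. Compound 3 is estimated at 96%, ranging from 85% to 100%.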

Compound 3, percent of the compound remaining: 90%
The estimate for compound 3 lay 6 percentage points above the measured number; low and high end bracket the measured number.
By their numbers in this assay, from the lowest: compounds 3, 1 and 2 (each within the scatter of the next).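

With methoxy in place of (tert-butyl)amino on the carbonyl carbon, this assay shows a number 6 percentage points lower from compound 1 to compound 3 (within the scatter). The carbamate tail, set against the bare hydrogen of the shorter compound, gives a number 10 percentage points lower from compound 2 to compound 3 (within the scatter). So a change at the end of the tail, and not only removal of the whole tail, leaves the reading within the scatter. No measurement here offers an explanation for these readings.

Going by these compounds, whether a tail ending in a carboxylic acid or an amine, or a longer chain, on the saturated chain carbon bound to a sulfonyl sulfur would also stay within the scatter remains open.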